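Switching the Chain on the Benzimidazole-Like Core's Nitrogen

This account rests on a few compounds, and the source may have more. Where it says the series, first, only, none or still open, it means among the compounds named here.

Compound 1 `CC(C)Cn1c(CN2CCN(C(=O)C3CC3)CC2)nc2ccccc21` has the lowest number of the three measured compounds in an assay on isolated protein for inhibition of aldehyde dehydrogenase 1A1 (Homo sapiens), read by spectrophotometry, tested at 10 uM (a higher number here means more inhibition at the concentration tested (going by the name of the read-out), a lower number less inhibition), where compound 1 gives 13.1%. Compound 2 `Cc1cccc(Cn2c(CN3CCN(C(=O)c4ccc(Br)cc4)CC3)nc3ccccc32)c1` gives 25.8% in this assay, and compound 3 `Cc1cccc(Cn2c(CN3CCN(C(=O)c4ccc(F)cc4)CC3)nc3ccccc32)c1` gives 27.1%. Within the data shown here, the only measured step between neighbours, a number 1.3 percentage points higher from compound 2 to compound 3 (within the scatter), concerns the amide end of the molecule and leaves the read-out essentially unchanged.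

Compound 4 `O=C(C1CC1)N1CCN(Cc2nc3ccccc3n2Cc2ccc(Cl)cc2)CC1` differs from compound 1 at the other end: 4-chlorophenyl in place of isopropyl on a saturated chain carbon bound to an aromatic nitrogen. Among the measured compounds shown here, no measured pair isolates this change, because compounds 2 and 3 carry both a benzyl group on that nitrogen and a different amide than compound 1, so their higher numbers cannot be assigned to one place alone. Still, the two compounds with an aromatic ring on that chain carbon both read higher than compound 1, which hints that the change in compound 4 is more likely to raise than to lower the number.

The step of a number 8.9 percentage points higher from compound 1 to compound 4 (within the scatter) is therefore expected to be a modest rise. Compound 4 is estimated at 22%, within a range from 8% to 38%.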

Compound 4, a percentage reported as inhibition, at one concentration (the size of the read-out at that concentration, not a potency): 56.6%
Estimate against measurement, compound 4: 34.6 percentage points below; the measured number lies above the stated range.
By their numbers in this assay, from the lowest: compound 1; then compounds 2 and 3 (each within the scatter of the next); then compound 4.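

In this assay, 4-chlorophenyl in place of isopropyl on a saturated chain carbon bound to an aromatic nitrogen gives a number 43.5 percentage points higher from compound 1 to compound 4 (beyond the scatter). This pair changes that position alone, with the amide end the same in both compounds, so it shows that this position can by itself move the read-out by a large amount, something compounds 2 and 3 could not show since they also differ from compound 1 at the amide end. Nothing measured here explains the size of this rise.

The change brings in an aromatic ring and a chlorine together, so the compounds shown leave open how much of the rise belongs to each. A plain benzyl group on that nitrogen would separate the two, and a 4-fluorobenzyl or 4-methoxybenzyl group would show whether another group can take the place of the chlorine.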